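The source may report more compounds than this note shows. Statements on the series, on what has been measured and on what is new or still open speak of the compounds shown alone.

Two measured compounds exist so far. In a functional assay on HEp-2 cells (Homo sapiens) for cytotoxicity, read by sulforhodamine B assay, with a stated time of 48 h (on this read-out higher numbers stand for weaker inhibition and lower numbers for stronger inhibition), compound 1 `CC(=O)N1N=C(c2ccco2)CC1c1ccc([N+](=O)[O-])cc1` gives 21800 nM, and compound 2 `O=CCN1N=C(c2ccc3ccccc3c2)CC1c1ccccc1` gives 8400 nM, the lower of the two numbers, with compound 1 standing further up by a margin beyond the scatter. Compound 3 `O=CCN1N=C(c2ccc3ccccc3c2)CC1c1cccc([N+](=O)[O-])c1` differs from compound 2 by nitro in place of hydrogen on an aromatic carbon. Within the data shown here, no step between measured compounds covers this change, and compound 1 carries its nitro on a different core and partner group, so it offers no direct guide. For compound 3 a step of no more than the usual scatter is expected, in either direction. Compound 3 is therefore estimated at 7000 nM, within a range from 2500 nM to 20000 nM, an expected step of a 1.2-fold lower number from compound 2 to compound 3 (0.08 log units; within the scatter).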

Compound 3, half-maximal inhibitory concentration: 3870 nM
Estimate against measurement, compound 3: 1.8-fold (0.26 log units) above; low and high end bracket the measured number.
By their numbers in this assay, from the lowest: compound 3; then compound 2; then compound 1.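

Phenyl to 3-nitrophenyl on the shared core gives a 2.2-fold lower number from compound 2 to compound 3 (0.34 log units; beyond the scatter) in this assay, so this aromatic carbon accepts nitro with a modest gain in inhibition rather than a loss. Among these compounds, this is the first single-place step; compound 1 could not show it, since its nitro stands on a different core. Nothing measured here bears on the reason for this step.

From the compounds shown here alone, whether the gain is specific to nitro or would also follow with an amine or a nitrile on the same carbon remains open. Also open, going by these compounds, is how nitro would read on the other carbons of this ring.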